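Swapping the piperidine substituent in a chemokine receptor antagonist series

The source may report more compounds than this note shows. Statements on the series, on what has been measured and on what is new or still open speak of the compounds shown alone.

Compound 1 `CNC(=O)c1cnc(N2CCN(C3CCN(Cc4cccs4)CC3)[C@@H](C)C2)c(Cl)c1` 1980 nM
Compound 2 `CNC(=O)c1cnc(N2CCN(C3CCN(Cc4ccccn4)CC3)[C@@H](C)C2)c(Cl)c1` 7990 nM
Compound 3 `CNC(=O)c1cnc(N2CCN(C3CCN(C(F)(F)F)CC3)[C@@H](C)C2)c(Cl)c1` 63 nM

Among the three measured compounds in a functional assay for antagonist activity at C-X-C chemokine receptor type 3 (Homo sapiens) (on this read-out higher numbers stand for weaker inhibition and lower numbers for stronger inhibition), compound 3 stands lowest, well apart from compound 1 (a 31-fold lower number from compound 1 to compound 3 (1.50 log units; beyond the scatter)) and from compound 2 (a 130-fold lower number from compound 2 to compound 3 (2.10 log units; beyond the scatter)). Compound 4 `CNC(=O)c1cnc(N2CCN(C3CCN(C(=O)c4ccc(Cl)cc4)CC3)[C@@H](C)C2)c(Cl)c1` differs from compound 3 by (4-chlorophenyl)carbonyl in place of trifluoromethyl on an amine nitrogen in a ring. As far as these compounds go, the measured steps only show that replacing an arylmethyl group on that nitrogen by trifluoromethyl gave large gains; none covers an aryl carbonyl there, so the new change is untested. The estimate leans on compound 3 being the nearest measured analogue, while allowing a higher number given the larger entering group. The expected step of a 2.4-fold higher number from compound 3 to compound 4 (0.38 log units; beyond the scatter) is modest. Compound 4 is estimated at 150 nM, in the range 25 nM to 900 nM.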

Compound 4, half-maximal inhibitory concentration: 210 nM
The estimate for compound 4 lay 1.4-fold (0.15 log units) below the measured number; the measured number falls inside the stated range.
By their numbers in this assay, from the lowest: compound 3; then compound 4; then compound 1; then compound 2.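

In this assay, (4-chlorophenyl)carbonyl on this amine nitrogen gives up only part of what trifluoromethyl gained, with a 3.3-fold higher number from compound 3 to compound 4 (0.52 log units; beyond the scatter). It still improves on both arylmethyl groups, with a 38-fold lower number from compound 2 to compound 4 (1.58 log units; beyond the scatter) and a 9.4-fold lower number from compound 1 to compound 4 (0.97 log units; beyond the scatter), so among these compounds an aromatic ring on this nitrogen does not by itself bring the high numbers of compound 1 and compound 2. Nothing available here explains these differences. The compounds shown leave open whether the carbonyl or the chlorine accounts for the difference from the arylmethyl groups, and how a sulfonyl link or a simple acetyl group on this nitrogen would compare.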